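The source may hold more compounds than are shown below. What is called first, only, known or untested is meant among the compounds shown, and "the series" means these compounds.

Measured compounds:
- compound 1 `O=Cc1ccc(OCCCOc2ccc(C=O)cc2)cc1`: 94.9%
- compound 2 `O=Cc1ccc(OCCCCCCCCCCCOc2ccc(C=O)cc2)cc1`: 93.3%

In an ADME assay on HepG2/C3A cells (Homo sapiens) for cytotoxicity, read by neutral red uptake, with a stated time of 24 h, tested at 60 uM (on this read-out lower numbers stand for a stronger effect and higher numbers for a weaker effect at the one concentration tested), compound 1 gives 94.9% and compound 2 gives 93.3%; the two values lie within the scatter of each other, so neither compound can be called stronger. Compound 2 stands at the lowest of the two numbers, compound 1 the nearest, its number only slightly higher.

Compound 3 `O=Cc1ccc(OCCCCCCCCCCCCOc2ccc(C=O)cc2)cc1` differs from compound 2 by (4-formylphenoxy)methyl in place of 4-formylphenoxy on a saturated chain carbon, ten or more bonds along the chain from an oxygen on an aromatic ring. Going by the values given here, no step between two measured compounds is known for this series. Given the two values at hand, the expectation for the step from compound 2 to compound 3 in this assay is none beyond the scatter, with a number 1.3 percentage points lower from compound 2 to compound 3 (within the scatter) as the estimated step. Compound 3 is expected to give 92%, in the range 82% to 100%.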

Compound 3, a percentage reported as activity, at one concentration (the size of the read-out at that concentration, not a potency): 101%
Compound 3: the middle estimate sits 9 percentage points below what was measured; the whole stated range lies below it.
By their numbers in this assay, from the lowest: compounds 2, 1 and 3 (each within the scatter of the next).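

In this assay, (4-formylphenoxy)methyl in place of 4-formylphenoxy on a saturated chain carbon, ten or more bonds along the chain from an oxygen on an aromatic ring, gives a number 7.7 percentage points higher from compound 2 to compound 3 (within the scatter). Going by these compounds alone, this is the only single-place step available, and it shows no effect of this change that can be told from the scatter at this position. Nothing on hand bears on the origin of this result.

From the compounds shown here alone, whether a much longer chain would move the read-out beyond the scatter remains open. The same holds for an amine or a carboxylic acid in place of a formyl group.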